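The compounds below may be only part of what the source reports. "The series", "measured", "known", "first", "only" and "open" are said of these compounds alone.

Series notes, measured set in a functional assay for antagonist activity at Oxoeicosanoid receptor 1 (Homo sapiens), read by fluorescence and calcium flux, with stated times of 2 min and 1 min; a lower number here means a stronger inhibitor, a higher number a weaker inhibitor:

compound 1 `CC(CC(=O)O)CC(=O)n1c(CCCc2ccccc2)cc2ccc(Cl)cc21` gives 210 nM
compound 2 `CC(CC(=O)O)CC(=O)n1c(CCCCCCc2ccccc2)cc2ccc(Cl)cc21` gives 12 nM
compound 3 `CC(CC(=O)O)CC(=O)c1c(CCCCc2ccccc2)n(C)c2ccc(Cl)cc12` gives 38 nM

Compound 2 stands lowest of the three in this assay; compound 3 is nearest, compound 1 furthest.

Next comes compound 4 `CC(CC(=O)O)CC(=O)n1c(CCCCc2ccccc2)cc2ccc(Cl)cc21`, which differs from compound 2 by phenyl in place of phenethyl on a saturated chain carbon, four bonds along the chain from an aromatic carbon, a shortening of the chain between the shared core and the terminal ring. Among the measured compounds shown here, the one bearing step runs the other way: lengthening the chain gave an 18-fold lower number from compound 1 to compound 2 (1.24 log units; beyond the scatter). Compound 3 carries the same four-carbon chain as compound 4 but on a differently substituted core, so its value only shows that such a chain length can sit between compound 1 and compound 2. A step upward is therefore expected, a 4.2-fold higher number from compound 2 to compound 4 (0.62 log units; beyond the scatter), smaller than the full measured lengthening. Compound 4 is estimated at 50 nM, range 20 nM to 150 nM.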

Compound 4, half-maximal inhibitory concentration: 18 nM
Estimate against measurement, compound 4: 2.8-fold (0.44 log units) above, and the stated range ends above it.
By their numbers in this assay, from the lowest: compounds 2 and 4 (each within the scatter of the next); then compound 3; then compound 1.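

In this assay, most of the drop seen with chain lengthening is already reached with the benzyl change, a 12-fold lower number from compound 1 to compound 4 (1.07 log units; beyond the scatter), and this step is large. Going on to the chain of compound 2 adds nothing resolvable, a 1.5-fold higher number from compound 2 to compound 4 (0.18 log units; within the scatter), so among compounds 1, 2 and 4 the sensitivity to length at this position lies in the shorter part of the range. No available evidence explains this. As far as these compounds go, whether a longer chain than that of compound 2 holds this level stays open, as does the effect of an amine within the chain or a fluorine on the terminal ring.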